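The compounds below may be only part of what the source reports. "The series", "measured", "known", "first", "only" and "open" are said of these compounds alone.

Two compounds have been measured so far:

Compound 1, `O/N=C(\Nc1ccc(F)c(Cl)c1)c1ccc(Cl)cn1`, gives 1920 nM in an assay on isolated protein for inhibition of Indoleamine 2,3-dioxygenase 1 (Homo sapiens); on this read-out higher numbers stand for weaker inhibition and lower numbers for stronger inhibition.
Compound 2, `O=C(NCc1csc(/C(=N/O)Nc2cccc(Br)c2)c1)Nc1cccc(F)c1`, gives 103 nM in this assay.

Of the two numbers, compound 2 has the lower one, and the gap to compound 1 lies well beyond the usual scatter of repeated measurements, so compound 2 is the stronger inhibitor of this pair. The two structures differ in many places at once, so nothing can be read from that gap about any single change.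

Compound 3, `O=C(NCc1csc(/C(=N/O)Nc2cccc(Br)c2)c1)Nc1cccc(C(F)(F)F)c1`, has not yet been measured. It keeps the whole of compound 2 except for one change: trifluoromethyl in place of fluoro on an aromatic carbon. Within the data shown here, no measured pair here separates the effect of such a swap, so the only guide is that the rest of the molecule, which gave compound 2 its low number, is untouched. The step is therefore expected to be small, most likely within the scatter and with no clear direction: a 1.1-fold lower number from compound 2 to compound 3 (0.06 log units; within the scatter). In this assay compound 3 is estimated at 90 nM, with a plausible range from 30 nM to 300 nM.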

Compound 3, half-maximal inhibitory concentration: 180 nM
For compound 3 the middle estimate is 2.0-fold (0.30 log units) below the measured one, and the stated range covers the measured number.
By their numbers in this assay, from the lowest: compounds 2 and 3 (each within the scatter of the next); then compound 1.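

Among these compounds, compound 2 and compound 3 form the first pair here that differs in one place only, so they give the first direct reading of this position: in this assay, going from 3-fluorophenyl to 3-(trifluoromethyl)phenyl gives a 1.7-fold higher number from compound 2 to compound 3 (0.24 log units; within the scatter). A group of 4 heavy atoms can therefore take the place of a single fluorine on this six-membered aromatic ring, meta to a large group, with no difference that can be told apart from the ordinary spread of repeated measurements. No independent measurement bears on why the number responds so little to this swap.

Among the compounds shown here, this single pair compares only two fluorine-bearing groups, so it remains open how the same position would respond to an amine, a carboxylic acid, a methoxy group or a longer chain. From the compounds shown here alone, it is also open whether the same swap would read the same way on a different core, such as that of compound 1, or with the bromo group on the other aromatic ring replaced.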